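The source may report more compounds than this note shows. Statements on the series, on what has been measured and on what is new or still open speak of the compounds shown alone.

Of the compounds shown here, two have been measured so far. Compound 1, `N#C/C(=C\N1CCN(C(=O)c2ccco2)C1=S)C(=O)Nc1ccc(Cl)cc1`, was tested in a functional assay on COLO 205 cells (Homo sapiens) for inhibition, read by sulforhodamine B assay, with a stated time of 48 h (a lower number here means a stronger inhibitor of growth, a higher number a weaker inhibitor of growth), and gave 25600 nM. Compound 2, `O=CN1CCN(c2ccc(Cl)cc2)C1=S`, a smaller molecule in which the shared core carries a chloro-substituted aromatic ring directly on one nitrogen, gave 20700 nM in this assay. Of the two numbers, that of compound 2 is the lower one, but the gap to compound 1 is within the scatter of repeated measurements, so the two compounds cannot be told apart on these data; both are weak inhibitors of growth.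

Compound 3, `O=CN1CCN(c2ccc(Cl)c(Cl)c2)C1=S`, differs from compound 2 in a single place: chloro in place of hydrogen on an aromatic carbon. For the measured compounds named here, no measured pair in this set shows what such an added chloro group does, so there is no step to lean on. The change is small, one heavy atom on an aromatic carbon, and in the absence of any related measurement the expectation is that the step from compound 2 to compound 3 stays near or within the scatter, with a 1.4-fold lower number from compound 2 to compound 3 (0.14 log units; within the scatter) as the estimated size. Compound 3 is therefore expected to give about 15000 nM in this assay, within a range from 5000 nM to 45000 nM.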

Compound 3, concentration for 50% growth inhibition: 20000 nM
Estimate against measurement, compound 3: 1.3-fold (0.12 log units) below; the range from low to high includes it.
By their numbers in this assay, from the lowest: compounds 3, 2 and 1 (each within the scatter of the next).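

In this assay, placing a chloro group in place of hydrogen on the aromatic carbon ortho to a chloro group and meta to a group of 8 heavy atoms gives a 1.0-fold lower number from compound 2 to compound 3 (0.01 log units; within the scatter), so compound 2 and compound 3 cannot be told apart. For the compounds shown here, this is the only step that can be read so far, and it shows that, at this position and on this compound, the added chloro group makes no difference this assay can detect; both compounds remain weak inhibitors of growth. No other measurement here speaks to why the result comes out this way.

A single step with one small group says nothing about how a different group on the same aromatic carbon would read, such as an amine, a carboxylic acid or a methoxy group. As far as these compounds go, it also remains open whether any change at this position can give a clearly stronger inhibitor of growth, or whether the same chloro group would read the same way on a compound with other groups on the shared core.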